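Methyl-Bearing Carboxyphenyl Tail on a Shared Core

The source may hold more compounds than are shown below. What is called first, only, known or untested is meant among the compounds shown, and "the series" means these compounds.

Three measured compounds share one core and differ only in the carboxyphenyl ring at the far end of the chain. In an assay on HEK293 cells for positive allosteric modulation of metabotropic glutamate receptor 3 (Rattus norvegicus), read by thallium flux, with a stated time of 2.5 min (on this read-out higher numbers stand for an effect only at larger amounts of compound and lower numbers for an effect already at smaller amounts), compound 1 `Cc1c(OCCCCOc2ccc(C(=O)O)cc2F)ccc(C(=O)CC(C)C)c1O` gives 1420 nM. In this assay compound 2 `Cc1c(OCCCCOc2ccc(C(=O)O)cc2Cl)ccc(C(=O)CC(C)C)c1O` gives 1140 nM, and compound 3 `Cc1c(OCCCCOc2cccc(C(=O)O)c2)ccc(C(=O)CC(C)C)c1O` gives 1430 nM. Among these three numbers compound 3 holds the highest, but every step between them is within the scatter: a 1.2-fold lower number from compound 1 to compound 2 (0.10 log units; within the scatter), a 1.0-fold higher number from compound 1 to compound 3 (0.00 log units; within the scatter) and a 1.3-fold higher number from compound 2 to compound 3 (0.10 log units; within the scatter). On the numbers shown, the three compounds cannot be told apart.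

Compound 4 `Cc1cc(OCCCCOc2ccc(C(=O)CC(C)C)c(O)c2C)ccc1C(=O)O` has not yet been measured in this assay. It differs from compound 3 in one place: 4-carboxy-3-methylphenyl in place of 3-carboxyphenyl on an oxygen on a saturated carbon. The measured steps that bear on this change are the two earlier exchanges of the carboxyphenyl ring, a 1.0-fold higher number from compound 1 to compound 3 (0.00 log units; within the scatter) and a 1.3-fold higher number from compound 2 to compound 3 (0.10 log units; within the scatter), both within the scatter. Since neither of those exchanges moved the number beyond the scatter, the expected step in this assay is a 1.0-fold higher number from compound 3 to compound 4 (0.02 log units; within the scatter), that is, no step beyond the scatter in either direction. Compound 4 is therefore estimated at 1500 nM in this assay, with a range from 700 nM to 3200 nM.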

Compound 4, half-maximal effective concentration: 3910 nM
Estimate against measurement, compound 4: 2.6-fold (0.42 log units) below; the whole stated range lies below it.
By their numbers in this assay, from the lowest: compounds 2, 1 and 3 (each within the scatter of the next); then compound 4.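

Among these compounds, the 4-carboxy-3-methylphenyl ring is the first group on this oxygen on a saturated carbon to move the number beyond the scatter in this assay, where a 2.7-fold higher number from compound 3 to compound 4 (0.44 log units; beyond the scatter) and a 3.4-fold higher number from compound 2 to compound 4 (0.54 log units; beyond the scatter) and also a 2.8-fold higher number from compound 1 to compound 4 (0.44 log units; beyond the scatter) all run in the same direction, towards an effect only at larger amounts of compound. A carboxyl group at the 4 position of the ring does not by itself go with this shift, since the 4-carboxy-2-fluorophenyl of compound 1 and the 4-carboxy-2-chlorophenyl of compound 2 both stay within the scatter of the 3-carboxyphenyl of compound 3, so the place is not indifferent to every change of ring after all, and among the rings shown only the methyl-bearing one departs. No measurement at hand gives a reason for this shift.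

On these data alone, what remains open is whether the methyl group itself carries the step or whether it depends on the methyl and the carboxyl group occurring together, a question that a plain 4-carboxyphenyl ring or a 3-carboxy-4-methylphenyl ring would address. Also open, as far as these compounds go, is whether a larger group in place of the methyl, such as ethyl or methoxy, would carry the number further in the same direction.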